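Swapping the benzyl of compound 1 for a carbocyclic group

The compounds below may be only part of what the source reports. "The series", "measured", "known", "first", "only" and "open" are said of these compounds alone.

In a functional assay (B cells) with Mus musculus as the target (a lower number here means that less compound is needed, a higher number that more compound is needed for the effect), compound 1 `C=CCn1c(=O)n(Cc2ccccc2)c2nc(N)nc(O)c21` gives 5 uM. Among the three measured compounds it stands second highest: compound 3 `C=CCn1c(=O)n([C@@H]2O[C@H](CO)[C@H]3OC(CCC)(CCC)O[C@H]32)c2nc(N)nc(O)c21`, which gives 4 uM, sits within the scatter of it, while compound 2 `Cn1c(=O)n([C@@H]2O[C@H](CO)[C@H]3OC(C)(C)O[C@H]32)c2nc(N)nc(O)c21`, at 168 uM, lies far beyond the scatter on the weaker side. Compound 4 `C=CCn1c(=O)n(C2CCC(CO)C2)c2nc(N)nc(O)c21` has not yet been tested in this assay. It differs from compound 1 in one place: a group of 7 heavy atoms (6 carbon, 1 oxygen; one five-membered non-aromatic ring of carbon only) in place of a group of 7 heavy atoms (7 carbon; one six-membered aromatic ring of carbon only), on an aromatic nitrogen. Compound 3 shows that a non-aromatic oxygen-bearing group on this nitrogen can keep the value low, so compound 4 is expected to stay near compound 1, with a step of a 1.6-fold higher number from compound 1 to compound 4 (0.20 log units; within the scatter) that is likely no larger than the scatter. The estimate for compound 4 is 8 uM, in a range from 2 uM to 30 uM.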

Compound 4, concentration for half-maximal effect: 226 uM
The estimate for compound 4 lay 28-fold (1.45 log units) below the measured number; the whole stated range lies below it.
By their numbers in this assay, from the lowest: compounds 3 and 1 (each within the scatter of the next); then compounds 2 and 4 (each within the scatter of the next).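

At this aromatic nitrogen, an equal count of heavy atoms does not preserve the result: in this assay the change from benzyl to the oxygen-bearing five-membered non-aromatic ring gives a 45-fold higher number from compound 1 to compound 4 (1.66 log units; beyond the scatter) with no change in net charge. This position therefore responds strongly to the identity of its group. No available evidence bears on the reason for this step. The compounds shown leave open whether the aromatic ring, the ring size or the oxygen carries the step. A cyclopentyl or cyclohexyl group on this nitrogen would help separate these.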